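The compounds below may be only part of what the source reports. "The series", "measured", "known", "first", "only" and "open" are said of these compounds alone.

Measured compounds and their values:

- compound 1 `NC[C@@H]1CCCc2cc(S(=O)(=O)c3cccc(F)c3)ccc21`: 0.0794 nM
- compound 2 `NC(=O)CNC[C@@H]1CCCc2cc(S(=O)(=O)c3cccc(F)c3)ccc21`: 0.1 nM
- compound 3 `O=S(=O)(O)CCCNC[C@@H]1CCCc2cc(S(=O)(=O)c3cccc(F)c3)ccc21`: 1.26 nM

All three were tested in an assay on isolated protein for displacement of a labelled ligand from 5-hydroxytryptamine receptor 6 (Homo sapiens); on this read-out lower numbers stand for stronger inhibition and higher numbers for weaker inhibition. On the numbers shown, compound 3 gives the highest number of the three: the step of a 16-fold higher number from compound 1 to compound 3 (1.20 log units; beyond the scatter) and the step of a 13-fold higher number from compound 2 to compound 3 (1.10 log units; beyond the scatter) both lie beyond the scatter, while the step of a 1.3-fold higher number from compound 1 to compound 2 (0.10 log units; within the scatter) does not. So compound 3 is the weakest binder among the measured compounds.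

Compound 4 `CC(C)(C)C(=O)NC[C@@H]1CCCc2cc(S(=O)(=O)c3cccc(F)c3)ccc21` has not yet been measured. It differs from compound 3 in one place: (tert-butyl)carbonyl in place of 3-sulfopropyl on an amine nitrogen.

Going by the values given here, two measured steps bear on this change, both from the side of what leaves. Removing the 3-sulfopropyl and putting hydrogen in its place, read backwards from the step of a 16-fold higher number from compound 1 to compound 3 (1.20 log units; beyond the scatter), gives a large lower number; swapping it for carbamoylmethyl, read backwards from the step of a 13-fold higher number from compound 2 to compound 3 (1.10 log units; beyond the scatter), does the same. Nothing measured tells what a (tert-butyl)carbonyl on this nitrogen does, so the expected step in this assay is uncertain, but the direction is more likely towards a lower number than towards a higher one.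

Compound 4 is therefore expected to come out at about 0.5 nM, with a range from 0.1 nM to 3 nM, an estimated step of a 2.5-fold lower number from compound 3 to compound 4 (0.40 log units; beyond the scatter).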

Compound 4, inhibition constant: 3.98 nM
Beside the measured number, compound 4's estimate is 8.0-fold (0.90 log units) below it; the whole stated range lies below it.
By their numbers in this assay, from the lowest: compounds 1 and 2 (each within the scatter of the next); then compound 3; then compound 4.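

In this assay, (tert-butyl)carbonyl on the amine nitrogen gives a 50-fold higher number from compound 1 to compound 4 (1.70 log units; beyond the scatter) and a 40-fold higher number from compound 2 to compound 4 (1.60 log units; beyond the scatter), whereas carbamoylmethyl showed only a 1.3-fold higher number from compound 1 to compound 2 (0.10 log units; within the scatter), so the four compounds now show that this position accepts some groups far better than others. The change also gives a 3.2-fold higher number from compound 3 to compound 4 (0.50 log units; beyond the scatter), which makes compound 4 the weakest binder of the four and shows that 3-sulfopropyl is not the least favourable group seen here, even though (tert-butyl)carbonyl has 6 heavy atoms against 7, so heavy-atom count alone does not set the order of these two groups. Nothing measured here explains why this change raises the number.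

The compounds shown leave open whether the loss follows the carbonyl attached to the nitrogen or the tert-butyl group, a question that a small acetyl group and a 2,2-dimethylpropyl chain on the same nitrogen would help to separate. They also leave open how a carboxylic acid at the end of a propyl chain, or a longer chain ending in an amine, would compare with the groups seen so far.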